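Furan acrylamides: aryl and pyridyl pairs in cytotoxicity

A few compounds are considered here, and "the series" means these few. Any claim that something is new, unique, unknown or untested is made for them only; others in the source may bear on it.

Measured compounds:
- compound 1, `C/C(=C\c1cc(-c2ccc(C)cc2)co1)C(N)=O`, in a functional assay on MCF7 cells (Homo sapiens) for cytotoxicity, read by CCK-8 assay, with a stated time of 24 h (a lower number here means a stronger inhibitor, a higher number a weaker inhibitor), compound 1 gives 1630 nM
- compound 2, `C/C(=C\c1cc(-c2ccc(F)cc2)co1)C(N)=O`, compound 2 gives 2210 nM
- compound 3, `C/C(=C\c1cc(-c2ccc(C)nc2)co1)C(N)=O`, compound 3 gives 10200 nM

Compound 1 and compound 2 differ by fluoro in place of methyl on an aromatic carbon, which gave a 1.4-fold higher number from compound 1 to compound 2 (0.13 log units; within the scatter). The difference between the core of compound 1 and the core of compound 3 is not broken down here; compound 3 simply stands highest of the three, beyond the scatter from both others.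

Compound 4, `C/C(=C\c1cc(-c2ccc(F)nc2)co1)C(N)=O`, is not yet measured. It differs from compound 3 by fluoro in place of methyl on an aromatic carbon. This is the same kind of change as from compound 1 to compound 2, not the same: here it sits on a six-membered aromatic ring with 1 nitrogen, next to the ring nitrogen, whereas there the ring was of carbon only.

In this assay the step is expected to be a 1.4-fold higher number from compound 3 to compound 4 (0.14 log units; within the scatter), a small step because a 1.4-fold higher number from compound 1 to compound 2 (0.13 log units; within the scatter) was small. Compound 4 is therefore estimated at 14000 nM, between 6000 nM and 35000 nM.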

Compound 4, half-maximal inhibitory concentration: 14100 nM
Compound 4: the middle estimate sits 1.0-fold (0.00 log units) below what was measured, within the range that was stated.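

In this assay fluoro in place of methyl gave a 1.4-fold higher number from compound 3 to compound 4 (0.14 log units; within the scatter) on the six-membered aromatic ring with 1 nitrogen, matching the step on the all-carbon ring: the same change on two cores in this assay, a 1.4-fold higher number (0.13 log units; within the scatter) from compound 1 to compound 2 and a 1.4-fold higher number (0.14 log units; within the scatter) from compound 3 to compound 4, 1.0-fold (0.01 log units) apart, within the scatter of two such steps. Both steps lie within the scatter, so the change stays small on these two cores, but neither step shows that fluoro and methyl truly differ. Two cores in a single assay do not establish that the step would stay small on other cores, nor do they account for the gap between compound 1 and compound 3.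

Open, going by these compounds, is whether an amine or a methoxy group on the same aromatic carbon would give a step beyond the scatter. Also open, on these data alone, is how a carboxylic acid in place of the amide would read.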